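Fluoro to cyano on the measured series

The source may hold more compounds than are shown below. What is called first, only, known or untested is meant among the compounds shown, and "the series" means these compounds.

Values measured in a functional assay on HT-29 cells (Homo sapiens) for antiproliferative activity, read by sulforhodamine B assay, with a stated time of 72 h (on this read-out lower numbers stand for stronger inhibition and higher numbers for weaker inhibition), are as follows

- Compound 1 `CCN1C(=O)CS/C1=N/Nc1nncc2ccccc12` gives 58 nM
- Compound 2 `O=S(=O)(Nc1ncccn1)c1ccc(Nc2nncc3ccccc23)cc1` gives 29 nM
- Compound 3 `Fc1ccc(Nc2nncc3ccccc23)cc1` gives 2.1 nM

Compound 3 has the lowest number of the three and so shows the strongest inhibition, with both other compounds higher by more than the scatter. The next step leads to compound 4 `N#Cc1ccc(Nc2nncc3ccccc23)cc1`, which carries cyano in place of fluoro on an aromatic carbon of a six-membered aromatic ring of carbon only, para to a large group. The counted difference is cyano in place of fluoro on an aromatic carbon in this exchange.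

Among the measured compounds shown here, no measured pair isolates a single change, so the expectation rests on little. Compound 2 at 29 nM in the table carries a larger group in place of the fluoro and lies higher than compound 3, which is one compound only and differs by more than the cyano exchange. A rise is therefore expected rather than a further drop. The estimated change is a 5.7-fold higher number from compound 3 to compound 4 (0.76 log units; beyond the scatter) in this assay and is expected to be a moderate weakening beyond the scatter. For compound 4 the estimated value is 12 nM with an expected range from 3 nM to 50 nM in this read-out.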

Compound 4, half-maximal inhibitory concentration: 1.2 nM
Compound 4: middle estimate off by 10-fold (1.00 log units), on the high side; measured number below the stated range.
By their numbers in this assay, from the lowest: compounds 4 and 3 (each within the scatter of the next); then compounds 2 and 1 (each within the scatter of the next).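

In this assay, among the compounds shown here, cyano in place of fluoro on an aromatic carbon, para to a large group, gives a 1.8-fold lower number from compound 3 to compound 4 (0.24 log units; within the scatter) and is the first comparison that isolates one change. Compound 3 gives 2.1 nM and compound 4 gives 1.2 nM, so the low number of compound 3 does not depend on fluoro alone, and this position takes cyano, with its additional heavy atom, triple bond and counted hydrogen-bond acceptor, without a shift that can be told from the scatter. Nothing available bears on why the two groups read alike.

As far as these compounds go, with only fluoro and cyano compared at this position, it remains open whether an amine, a carboxylic acid or a methoxy group on the same aromatic carbon would hold the number in this assay at the level of compound 3 and compound 4. Also open, from the compounds shown here alone, is whether plain hydrogen or a longer chain at this carbon would do the same, and so whether the group here matters at all.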